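A few compounds are considered here, and "the series" means these few. Any claim that something is new, unique, unknown or untested is made for them only; others in the source may bear on it.

For the measured compounds named here, compound 2 `O=C1CC(c2cccc(NC(=O)Nc3ccc(Cl)cc3)c2)=Nc2cscc2N1` gives 4550 nM in a functional assay on U-937 cells (Homo sapiens) for antiproliferative activity, read by MTT assay, with a stated time of 24 h; a higher number here means a weaker inhibitor of growth, a lower number a stronger inhibitor of growth; this is the lower of the two numbers known, the only neighbour being compound 1 `O=C1CC(c2cccc(NC(=O)Nc3ccc(Cl)c(C(F)(F)F)c3)c2)=Nc2cscc2N1`, which in this assay gives 14300 nM. The two differ in one place, and that step, a 3.1-fold lower number from compound 1 to compound 2 (0.50 log units; beyond the scatter), is the only one measured so far. Compound 3 `O=C1CC(c2cccc(NC(=O)Nc3ccc(Cl)c(Cl)c3)c2)=Nc2cscc2N1` carries chloro in place of hydrogen on an aromatic carbon. The chloro group enters at the very carbon that holds trifluoromethyl in compound 1, so that step bears directly on this one: a group at that carbon raised the number moderately, and the new group is smaller than trifluoromethyl. A rise of a smaller size is therefore expected for compound 3, perhaps not clearly beyond the scatter, as a 1.5-fold higher number from compound 2 to compound 3 (0.19 log units; within the scatter). In this assay compound 3 is estimated at 7000 nM, with a likely range from 3000 nM to 16000 nM.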

Compound 3, concentration for 50% growth inhibition: 3200 nM
Beside the measured number, compound 3's estimate is 2.2-fold (0.34 log units) above it; the measured number falls inside the stated range.
By their numbers in this assay, from the lowest: compounds 3 and 2 (each within the scatter of the next); then compound 1.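

In this assay, a group on the aromatic carbon ortho to a chloro group does not by itself go with a higher number: placing chloro there gives a 1.4-fold lower number from compound 2 to compound 3 (0.15 log units; within the scatter), so hydrogen and chloro cannot be told apart at this carbon. The identity of the group still counts, as the exchange of trifluoromethyl for chloro gives a 4.5-fold lower number from compound 1 to compound 3 (0.65 log units; beyond the scatter), although this rests on a single pair. Nothing measured here accounts for the gap between chloro and trifluoromethyl.

Only hydrogen, chloro and trifluoromethyl are shown at this carbon, so it remains open whether a fluoro, methyl, methoxy or amine group there would match hydrogen and chloro or trifluoromethyl. Going by these compounds, all three compounds also keep the other chloro group, so it is unknown whether these steps would hold with a different group in its place.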